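From amide to urea: estimating compound 4

The source may report more compounds than this note shows. Statements on the series, on what has been measured and on what is new or still open speak of the compounds shown alone.

Measured compounds:
compound 1 `COc1cc(-c2nn(-c3cccc(NC(=O)c4cccc(C(F)(F)F)c4)c3)cc2-c2ccncc2)ccc1Cl` gives > 50000 nM in a functional assay on IGROV-1 cells (Homo sapiens) for inhibition, read by sulforhodamine B assay, with a stated time of 48 h; a lower number here means a stronger inhibitor of growth, a higher number a weaker inhibitor of growth.
compound 2 `O=C(Nc1cccc(-n2cc(-c3ccncc3)c(-c3ccc(Cl)c(O)c3)n2)c1)Nc1cc(C(F)(F)F)cc(C(F)(F)F)c1` gives 3550 nM.
compound 3 `O=C(Nc1cccc(-n2cc(-c3ccncc3)c(-c3ccc(Cl)c(O)c3)n2)c1)Nc1cccc(C(F)(F)F)c1` gives > 32500 nM.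

For compound 1 the value is only a limit of the assay, not a number, sitting at the limit of > 50000 nM in this assay, at which 1 of the 3 values shown sits. Compound 3 likewise stops at a limit, at the limit of > 32500 nM in this assay, at which 1 of the 3 values shown sits. Compound 2 is the only one of the three with a number.

Compound 4 `COc1cc(-c2nn(-c3cccc(NC(=O)Nc4ccc(Cl)c(Cl)c4)c3)cc2-c2ccncc2)ccc1Cl` has not yet been measured. It differs from compound 1 by (3,4-dichlorophenyl)amino in place of 3-(trifluoromethyl)phenyl on a carbonyl carbon. Going by the values given here, no measured step matches this change directly, since compounds 2 and 3 also differ from compound 4 elsewhere in their structures. Among the compounds with values here, the one measured step that bears on it is an at least 9.1-fold higher number from compound 2 to compound 3 (0.96 log units; beyond the scatter), showing that the pattern of groups on the outer ring of a urea can move the result from a number to a limit. Compound 4 carries a urea, as compounds 2 and 3 do, but with two chlorines on that ring.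

A modest gain over the limit of compound 1 is expected, though the risk of another limit remains. Compound 4 is estimated at 20000 nM, within 4000 nM to 60000 nM, which would mean the expected step of an at least 2.5-fold lower number from compound 1 to compound 4 (0.39 log units; beyond the scatter).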

Compound 4, concentration for total growth inhibition: 3480 nM
Compound 4: middle estimate off by 5.7-fold (0.76 log units), on the high side; the measured number lies below the stated range.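

In this assay, putting (3,4-dichlorophenyl)amino in place of 3-(trifluoromethyl)phenyl on this carbonyl carbon gives an at least 14-fold lower number from compound 1 to compound 4 (1.15 log units; beyond the scatter) and turns a limit into a real number on the core of compound 1. Going by these compounds alone, the starting point of that step is only a limit, the one for compound 1: the limit of > 50000 nM in this assay, at which 1 of the 4 values shown sits. The earlier step of an at least 9.1-fold higher number from compound 2 to compound 3 (0.96 log units; beyond the scatter) changed only the outer ring of a urea, whereas this one turns an amide into a urea and alters the groups on the outer ring in a single move.

The compounds shown do not separate the effect of the added amide-type nitrogen from that of the two chlorines: this one step carries both. They also leave open how the result would shift with other groups on that outer ring, such as a nitrile or a carboxylic acid.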